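A few compounds are considered here, and "the series" means these few. Any claim that something is new, unique, unknown or untested is made for them only; others in the source may bear on it.

Measured compounds:
Compound 1 `C#CCSc1nc(Nc2cccc(C(F)(F)F)c2)c(C#N)c(-c2ccccc2)n1` gives in a functional assay on MGC-803 cells (Homo sapiens) for inhibition, read by MTT assay, with a stated time of 72 h (on this read-out lower numbers stand for stronger inhibition and higher numbers for weaker inhibition), only a limit, > 128000 nM.
Compound 2 `C#CCSc1nc(Nc2cccc(Cl)c2)c(C#N)c(-c2ccccc2)n1` gives in this assay likewise only a limit, > 128000 nM.
Compound 3 `N#Cc1c(Nc2ccccc2Cl)nc(SCc2cn(Cc3ccccc3Cl)nn2)nc1-c1ccccc1` gives in this assay 4640 nM.

Going by the values given here, compound 3 therefore holds the only number in this assay; the other two values are limits, as noted in the limit of > 128000 nM in this assay, at which 2 of the 3 values shown sit. Among the compounds with values here, the single step between measured compounds, a step that the two limits leave unreadable from compound 1 to compound 2, cannot be read in size, both of its ends sitting at the limit described in the limit of > 128000 nM in this assay, at which 2 of the 3 values shown sit. It concerns the substituent on the anilino ring, but in a pair that also carries a different thioether group from compound 3, so it gives no usable guide for the present change.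

Compound 4 `Cc1cccc(Nc2nc(SCc3cn(Cc4ccccc4Cl)nn3)nc(-c3ccccc3)c2C#N)c1` differs from compound 3 by 3-methylphenyl in place of 2-chlorophenyl on a nitrogen on an aromatic ring. Within the data shown here, no measured step with a readable size bears on this change. With nothing to point either way, the expected step is a 1.3-fold higher number from compound 3 to compound 4 (0.11 log units; within the scatter), not beyond the usual scatter, with wide uncertainty on both sides. Compound 4 is thus estimated to give in this assay 6000 nM, with a range from 1500 nM to 25000 nM.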

Compound 4, half-maximal inhibitory concentration: 16200 nM
For compound 4 the middle estimate is 2.7-fold (0.43 log units) below the measured one; low and high end bracket the measured number.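

In this assay, going by these compounds alone, the change from (2-chlorophenyl)amino to (3-methylphenyl)amino gives the first step of readable size on this nitrogen, a 3.5-fold higher number from compound 3 to compound 4 (0.54 log units; beyond the scatter), whereas the earlier step between compound 1 and compound 2 cannot be read. The aryl group at this place therefore shifts the number while the rest of the structure stays fixed, although this rests on a single pair, and compound 4 remains measurable rather than falling to a limit. Nothing shown bears on why this step has its size.

The exchange replaces the chlorine with a methyl group and also changes the ring's substitution, so the compounds shown cannot separate the contribution of the substituent's identity from that of its location. Open too, going by these compounds, are how an unsubstituted phenyl group, or a phenyl group carrying a carboxylic acid or an amine, would read at this nitrogen, and whether the same step would appear with the thioether group of compound 1 and compound 2 in place of that of compound 3.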